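Shortening the Ester Chain: Expected Cytotoxicity of Compound 3

The compounds below may be only part of what the source reports. "The series", "measured", "known", "first", "only" and "open" are said of these compounds alone.

Measured in an ADME assay on Vero cells (Chlorocebus sabaeus) for cytotoxicity, read by MTT assay, with a stated time of 3 days; on this read-out higher numbers stand for weaker inhibition and lower numbers for stronger inhibition:
Compound 1 `CCCCCCCC(=O)OC[C@@H]1OC[C@H](n2cc(C)c(=O)[nH]c2=O)O1` reads > 100000 nM, which is a limit of the assay rather than a number.
Compound 2 `CCCCC(=O)OC[C@@H]1OC[C@H](n2cc(C)c(=O)[nH]c2=O)O1` gives 49000 nM.

Compound 2 therefore stands on the only number shown in this assay; the other value sits at the limit of > 100000 nM in this assay, at which 1 of the 2 values shown sits. Compound 3 `CC(=O)OC[C@@H]1OC[C@H](n2cc(C)c(=O)[nH]c2=O)O1` differs from compound 2 by hydrogen in place of propyl on a saturated chain carbon bound to a carbonyl carbon. For the measured compounds named here, only one measured step bears on this change: the earlier shortening of the same chain gave an at least 2.0-fold lower number from compound 1 to compound 2 (0.30 log units; that floor lies within the scatter), a step that starts from a limit and reaches no further than the usual scatter. That step offers little to build on, so the change is estimated to bring a 1.2-fold higher number from compound 2 to compound 3 (0.09 log units; within the scatter), a shift not clearly beyond the scatter in either direction. Compound 3 is expected to give about 60000 nM in this assay, with a likely range from 20000 nM to 150000 nM.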

Compound 3, half-maximal inhibitory concentration: > 100000 nM
Compound 3 ended at the assay's limit (the forecaster's own chance of this, stated with the estimate: 40%); middle value at least 1.6-fold (0.22 log units) from the limit.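

At the saturated chain carbon bound to a carbonyl carbon, hydrogen in place of propyl gives an at least 2.0-fold higher number from compound 2 to compound 3 (0.30 log units; that floor lies within the scatter) in this assay. This runs opposite to the earlier shortening of the same chain, an at least 2.0-fold lower number from compound 1 to compound 2 (0.30 log units; that floor lies within the scatter), so shortening does not simply keep lowering the number, although neither floor goes beyond the scatter and this remains only a hint. The step from compound 1 to compound 3 cannot be read, and the longest and shortest chains shown both end at the limit: the limit of > 100000 nM in this assay, at which 2 of the 3 values shown sit.

As far as these compounds go, how far compound 1 and compound 3 lie past that limit stays open, and with it whether compound 2 marks a true low point. The compounds shown also leave open how an amine or a carboxylic acid at the end of the chain would read.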